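Methyl on a phenol oxygen: compound 3 to compound 4

The compounds below may be only part of what the source reports. "The series", "measured", "known", "first", "only" and "open" are said of these compounds alone.

Measured in a functional assay on NCI-H157 cells (Homo sapiens) for cytotoxicity, read by resazurin assay, with a stated time of 72 h (on this read-out higher numbers stand for weaker inhibition and lower numbers for stronger inhibition), as follows
compound 1 `O=C(/C=C/c1ccc(OCCCCCO[N+](=O)[O-])c(O)c1)OCCCCCO[N+](=O)[O-]` gives > 50000 nM
compound 2 `COc1cc(/C=C/C(=O)OCCCO[N+](=O)[O-])ccc1OCCCO[N+](=O)[O-]` gives > 50000 nM
compound 3 `O=C(/C=C/c1ccc(O)c(O)c1)OCc1c(-c2ccccc2)no[n+]1[O-]` gives > 50000 nM

All three entries are limits of the assay and not numbers, so none of these compounds can be ranked against another. The shared position is the limit of > 50000 nM in this assay, at which 3 of the 3 values shown sit. Compound 3 stands at > 50000 nM, which is a limit, and no number is available for it.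

The next compound is compound 4 `COc1cc(/C=C/C(=O)OCc2c(-c3ccccc3)no[n+]2[O-])ccc1O`. It differs from compound 3 by methyl in place of hydrogen on an oxygen on an aromatic ring, with methyl in place of hydrogen on an oxygen on an aromatic ring, which turns 3,4-dihydroxyphenyl into 4-hydroxy-3-methoxyphenyl.

Going by the values given here, no measured pair shows this change or any other single change, so its size cannot be read from the data. The expectation rests only on compound 3 at > 50000 nM as its starting limit. No step beyond the scatter is expected in this assay, and a further limit is the most likely report. The expected change is a number no higher from compound 3 to compound 4 (the limit leaves the size open) in size. For compound 4 the estimated value is 50000 nM, with an expected range from 20000 nM to 100000 nM.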

Compound 4, half-maximal inhibitory concentration: 4530 nM
For compound 4 the middle estimate is 11-fold (1.04 log units) above the measured one; measured number below the stated range.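

In this assay, methyl in place of hydrogen on an oxygen on an aromatic ring, which turns 3,4-dihydroxyphenyl into 4-hydroxy-3-methoxyphenyl, gives an at least 11-fold lower number from compound 3 to compound 4 (1.04 log units; beyond the scatter). Going by these compounds alone, this is the first single change that can be read, and it shows that this position is sensitive: hydroxy to methoxy here, with the rest of the molecule unchanged, is enough to move the read-out from a limit of the assay to a number. Compound 4 is therefore the only compound shown with a number, and the others remain at a limit: the limit of > 50000 nM in this assay, at which 3 of the 4 values shown sit.

The step has only a lower bound on its size, and a single pair gives no trend, so nothing yet says how far the effect of this change extends. On these data alone, it remains open whether ethyl or a longer chain on the same oxygen, methyl on the remaining hydroxy, or an amine in place of that hydroxy would keep, strengthen or lose the inhibition seen with compound 4, and whether the same change would have any effect on the cores of compound 1 or compound 2.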